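This account rests on a few compounds, and the source may have more. Where it says the series, first, only, none or still open, it means among the compounds named here.

Measured compounds:
compound 1 `O=C(Nc1ccc(C(F)(F)F)cc1)c1cc(Cl)c(-c2ccccc2)cc1O`: 490 nM
compound 2 `N#Cc1ccc(NC(=O)c2cc(Br)c(-c3ccccc3)cc2O)cc1`: 700 nM

In a functional assay on HL-60 cells (Homo sapiens) for cytotoxicity, read by luminescence and CellTiter-Glo, with a stated time of 3 days (on this read-out higher numbers stand for weaker inhibition and lower numbers for stronger inhibition), compound 2 gives 700 nM, the highest of the two numbers, although its gap to compound 1, which gives 490 nM, lies within the scatter. Compound 3 `N#Cc1ccc(NC(=O)c2cc(Cl)c(-c3ccccc3)cc2O)cc1` awaits measurement. It differs from compound 2 by chloro in place of bromo on an aromatic carbon. Going by the values given here, no measured pair shows this exchange, so nothing here supports a move in either direction; the step of no change at the digits printed from compound 2 to compound 3 (within the scatter) is expected to stay within the scatter. Compound 3 is accordingly estimated at 700 nM, with a range from 350 nM to 1400 nM.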

Compound 3, half-maximal inhibitory concentration: 520 nM
Compound 3: the middle estimate sits 1.3-fold (0.13 log units) above what was measured; the measured number falls inside the stated range.
By their numbers in this assay, from the lowest: compounds 1, 3 and 2 (each within the scatter of the next).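

In this assay, chloro in place of bromo on the aromatic carbon ortho to a phenyl group gives a 1.3-fold lower number from compound 2 to compound 3 (0.13 log units; within the scatter) and leaves the two halogens inseparable on this read-out. Compound 3 also isolates the other exchange, since cyano in place of trifluoromethyl gives a 1.1-fold higher number from compound 1 to compound 3 (0.03 log units; within the scatter) and likewise stays within the scatter. Nothing available offers an explanation for either step. Going by these compounds, whether an amine or a carboxylic acid on that same aromatic carbon would keep the number in this range remains open, as does the effect of a methoxy group in place of the cyano.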